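This account rests on a few compounds, and the source may have more. Where it says the series, first, only, none or still open, it means among the compounds named here.

Measured so far:
compound 1, `COc1ccc(/C=N/c2c(C#N)ncn2Cc2ccc(F)cc2)cc1`, 9190 nM
compound 2, `COc1ccc(/C=N/c2c(C#N)ncn2Cc2ccc(F)cc2)cc1OC`, 13800 nM
compound 3, `COc1ccc(C2N=C(C(N)=O)c3ncn(-c4ccc(F)cc4)c3N2)cc1`, 11000 nM

All three were tested in a functional assay on HT-29 cells (Homo sapiens) for antiproliferative activity, read by MTT assay, with a stated time of 48 h; a higher number here means a weaker inhibitor, a lower number a stronger inhibitor. Compound 1 and compound 2 share one core; compound 3 rests on a different core, and the difference between the two cores is not broken down here. In this assay compound 1 gives 9190 nM, compound 2 gives 13800 nM and compound 3 gives 11000 nM. These three numbers lie close together, and none of them stands apart from the others by more than the usual scatter.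

One change has already been seen once. Going from compound 1 to compound 2 the change is methoxy in place of hydrogen on an aromatic carbon, and it made a 1.5-fold higher number from compound 1 to compound 2 (0.18 log units; within the scatter). Compound 4, `COc1ccc(C2N=C(C(N)=O)c3ncn(-c4ccc(F)cc4)c3N2)cc1OC`, is compound 3 with the same change, (methoxy in place of hydrogen on an aromatic carbon). The surroundings of the place are described in the same words for both pairs, so this is the same change made on a different core.

For the measured compounds named here, the expectation for compound 4 rests on compound 3 with 11000 nM and on the single earlier step of a 1.5-fold higher number from compound 1 to compound 2 (0.18 log units; within the scatter). Since that step stayed within the scatter, the step from compound 3 to compound 4 is also expected to be small, about a 1.4-fold higher number from compound 3 to compound 4 (0.13 log units; within the scatter). Compound 4 is therefore expected to give roughly 15000 nM in this assay, most likely somewhere between 7000 nM and 35000 nM.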

Compound 4, half-maximal inhibitory concentration: 3290 nM
Estimate against measurement, compound 4: 4.6-fold (0.66 log units) above; measured number below the stated range.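

In this assay, placing a methoxy on the aromatic carbon ortho to the existing methoxy group gives a 3.3-fold lower number from compound 3 to compound 4 (0.52 log units; beyond the scatter), a step large enough to stand out from the usual scatter. Set beside the earlier step, this shows that the same change does not carry over from one core to the other with the same effect, so a step seen on the core of compound 1 was a poor guide on the core of compound 3: the same change on two cores in this assay, a 1.5-fold higher number (0.18 log units; within the scatter) from compound 1 to compound 2 and a 3.3-fold lower number (0.52 log units; beyond the scatter) from compound 3 to compound 4, 5.0-fold (0.70 log units) apart, beyond the scatter of two such steps. For the compounds shown here, the comparison rests on only two pairs of compounds, so it does not show why the two cores respond differently, nor how the change would behave on any further core, and it says nothing about cells other than those used here.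

The compounds shown leave open whether the lower number on the core of compound 3 is tied to methoxy itself, since a hydroxyl group, a fluorine atom, an amine or a longer chain such as ethoxy at the same place could behave differently. They also leave open whether any of these groups would give a step beyond the scatter on the core of compound 1, where methoxy did not.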